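Shortening a Chain on a Shared Core

A few compounds are considered here, and "the series" means these few. Any claim that something is new, unique, unknown or untested is made for them only; others in the source may bear on it.

Compound 1 `COc1nc2ccc(Br)cc2cc1C(c1ccccc1)n1cc(-c2ccccc2F)nn1`, compound 2 `CCCCCCCc1cn(C(c2ccccc2)c2cc3cc(Br)ccc3nc2OC)nn1` and compound 3 `COc1nc2ccc(Br)cc2cc1C(c1ccccc1)n1cc(-c2ccc(OC(F)(F)F)cc2)nn1` share one core and differ only in the group attached to a single aromatic carbon. In an ADME assay on SK-OV-3 cells (Homo sapiens) for cytotoxicity, read by sulforhodamine B assay, with a stated time of 48 h, tested at 10 uM (a lower number here means less inhibition, a higher number more inhibition at the concentration tested (going by the name of the read-out)), compound 1 gives 7.33%, compound 2 gives 10.5% and compound 3 gives 14.8%. Compound 2 stands between the other two, but the step of a number 3.2 percentage points higher from compound 1 to compound 2 (within the scatter) and the step of a number 4.3 percentage points higher from compound 2 to compound 3 (within the scatter) both lie within the scatter, as does the step of a number 7.5 percentage points higher from compound 1 to compound 3 (within the scatter). Compound 4 `CCCc1cn(C(c2ccccc2)c2cc3cc(Br)ccc3nc2OC)nn1` differs from compound 2 by hydrogen in place of butyl on a saturated chain carbon, three bonds along the chain from an aromatic carbon. Going by the values given here, no measured step shortens or lengthens this chain; the three measured steps exchange the whole group on that aromatic carbon, and even those stay within the scatter. Compound 4 is therefore expected to show no step beyond the scatter in this assay, and the expected step is a number 0.5 percentage points lower from compound 2 to compound 4 (within the scatter). The estimate for compound 4 is 10%, with a range from 0% to 22%.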

Compound 4, a percentage reported as inhibition, at one concentration (the size of the read-out at that concentration, not a potency): 11.2%
Estimate against measurement, compound 4: 1.2 percentage points below; low and high end bracket the measured number.
By their numbers in this assay, from the lowest: compounds 1, 2, 4 and 3 (each within the scatter of the next).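

In this assay the change from heptyl to propyl, the only step shown that alters the chain itself, gives a number 0.7 percentage points higher from compound 2 to compound 4 (within the scatter) and so adds a shortening of the chain to the whole-group exchanges already seen at this position. Compound 4 also stays within the scatter of the two compounds with aromatic groups, with a number 3.6 percentage points lower from compound 3 to compound 4 (within the scatter) and a number 3.9 percentage points higher from compound 1 to compound 4 (within the scatter) as its steps, so propyl does not separate from heptyl, 2-fluorophenyl or 4-(trifluoromethoxy)phenyl on that aromatic carbon. Nothing in the data explains this absence of separation.

The compounds shown leave open whether an amine or a carboxylic acid on that aromatic carbon would give a step beyond the scatter. They also leave open whether a chain ending in a hydroxyl group would do so.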